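Cytotoxicity series: amine substituent on the shared core

The source may hold more compounds than are shown below. What is called first, only, known or untested is meant among the compounds shown, and "the series" means these compounds.

Measured so far in an ADME assay on cells (Homo sapiens) for cytotoxicity, read by polymerase chain reaction, with a stated time of 3 days; a lower number here means that less compound is tolerated, a higher number that more compound is tolerated: compound 1 `Cc1nc(NCC(C)C)nc(N[C@@H]2C[C@H](CO)[C@@H](O)[C@H]2O)c1-c1nc2ccccc2s1` gives 10000 nM. Compound 2 `Cc1nc(Nc2ccccc2)nc(N[C@@H]2C[C@H](CO)[C@@H](O)[C@H]2O)c1-c1nc2ccccc2s1` gives > 25000 nM, a limit of this assay. Compound 3 `Cc1nc(Nc2ncco2)nc(N[C@@H]2C[C@H](CO)[C@@H](O)[C@H]2O)c1-c1nc2ccccc2s1` gives > 25000 nM, likewise a limit.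

Compound 3 thus sits at the limit of > 25000 nM in this assay, at which 2 of the 3 values shown sit, with only a limit known. The next change is (thiophen-2-yl)methyl in place of 1,3-oxazol-2-yl on a nitrogen on an aromatic ring, giving compound 4 `Cc1nc(NCc2cccs2)nc(N[C@@H]2C[C@H](CO)[C@@H](O)[C@H]2O)c1-c1nc2ccccc2s1`. Among the compounds with values here, the steps that bear on it, an at least 2.5-fold higher number from compound 1 to compound 2 (0.39 log units; beyond the scatter) and an at least 2.5-fold higher number from compound 1 to compound 3 (0.39 log units; beyond the scatter), both rose beyond the scatter, while a step that the two limits leave unreadable from compound 2 to compound 3 cannot be read. Compound 4 carries a methylene-linked aromatic group, nearer in kind to the isobutyl of compound 1 than to the directly attached rings of compound 2 and compound 3, so a modest fall in this assay is expected, an at least 1.6-fold lower number from compound 3 to compound 4 (0.22 log units; that floor lies within the scatter). For compound 4 the estimate is 15000 nM, between 6000 nM and 30000 nM.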

Compound 4, half-maximal cytotoxic concentration: 6000 nM
Estimate against measurement, compound 4: 2.5-fold (0.40 log units) above; low and high end bracket the measured number.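

Swapping the directly attached rings for (thiophen-2-yl)methyl on this nitrogen gives an at least 4.1-fold lower number from compound 3 to compound 4 (0.61 log units; beyond the scatter) and an at least 4.1-fold lower number from compound 2 to compound 4 (0.61 log units; beyond the scatter). The change from isobutyl gives a 1.7-fold lower number from compound 1 to compound 4 (0.22 log units; within the scatter), so compound 1 and compound 4 cannot be told apart. In these four compounds, the two groups attached through a saturated chain carbon read lower than the directly attached rings, which remain at a limit: the limit of > 25000 nM in this assay, at which 2 of the 4 values shown sit.

The step between compound 2 and compound 3 cannot be read. From the compounds shown here alone, whether a benzyl group would read like compound 4 or like compound 2 remains open.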